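This account rests on a few compounds, and the source may have more. Where it says the series, first, only, none or still open, it means among the compounds named here.

In a functional assay on A549 cells (Homo sapiens) for inhibition, read by MTT assay, with a stated time of 72 h (on this read-out lower numbers stand for stronger inhibition and higher numbers for weaker inhibition), compound 2 `Nc1nc2cc(-c3nn(CCCCCCCCCC(=O)NO)c4ncnc(N)c34)ccc2o1` gives > 50000 nM, which is a limit of the assay and not a number. Compound 4 `Nc1nc2cc(-c3nn(CCCCC(=O)NO)c4ncnc(N)c34)ccc2o1` keeps its aromatic groups and shortens its chain: hydroxycarbamoyl in place of 5-(hydroxycarbamoyl)pentyl on a saturated chain carbon, four bonds along the chain from an aromatic nitrogen. Going by the values given here, the one measured step, an at least 7.6-fold lower number from compound 2 to compound 3 (0.88 log units; beyond the scatter), changes the aromatic group rather than the chain, so it bears only indirectly, showing that the long chain alone does not secure a number. Chain length is touched only by a comparison on another core. There, compound 3 `Nc1ncnc2c1c(-c1cnc3[nH]ccc3c1)nn2CCCCCCCCCC(=O)NO`, with the long chain, gives 6550 nM. Compound 1 `Nc1ncnc2c1c(-c1cnc3[nH]ccc3c1)nn2CC(=O)NO`, with the shortest chain, gives > 150000 nM, also a limit. That pair suggests shortening does not help, so no gain is expected here, and an estimated step that the limit leaves unreadable from compound 2 to compound 4 would be small and towards weaker inhibition. Compound 4 is expected near 80000 nM, with an estimated range of 25000 nM to 200000 nM, and most likely only a limit will be reported.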

Compound 4, half-maximal inhibitory concentration: > 100000 nM
Compound 4 ended at the assay's limit (the forecaster's own chance of this, stated with the estimate: 75%); middle value at least 1.2-fold (0.09 log units) away from the limit.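

In this assay compound 4 gives > 100000 nM, which is a limit of the assay and not a number. Compound 2 also stands at a limit, so the step between the two cannot be read. The compounds shown leave open whether chain length changes inhibition at all on the core of compound 2.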